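Cytotoxicity series: replacing the dichlorophenyl amide of compound 3

The source may hold more compounds than are shown below. What is called first, only, known or untested is meant among the compounds shown, and "the series" means these compounds.

Compound 1 `Cc1ccccc1C(=O)Nc1ccc2nc(NC(=O)C3CCCCC3)sc2c1` gives 0.085 ug/mL in a functional assay on WI-38 VA13 cells (Homo sapiens) for cytotoxicity; on this read-out higher numbers stand for an effect only at larger amounts of compound and lower numbers for an effect already at smaller amounts. Compound 2 `COc1ccc(C(=O)Nc2ccc3nc(NC(=O)C4CCCCC4)sc3c2)cc1` gives 4.9 ug/mL in this assay, a change of a 58-fold higher number from compound 1 to compound 2 (1.76 log units; beyond the scatter). Compound 3 `O=C(Nc1ccc2nc(NC(=O)C3CCCCC3)sc2c1)c1ccc(Cl)cc1Cl` gives only > 4 ug/mL in this assay, which is a limit of the measurement and not a number. Compound 3 thus sits at the limit (the limit of > 4 ug/mL in this assay, at which 1 of the 3 values shown sits), and against compound 1 the step is an at least 47-fold higher number from compound 1 to compound 3 (1.67 log units; beyond the scatter). The step that the limit leaves unreadable from compound 2 to compound 3 cannot be sized. Compound 4 `Cc1[nH][n+](C)c(C)c1C(=O)Nc1ccc2nc(NC(=O)C3CCCCC3)sc2c1` differs from compound 3 by a group of 8 heavy atoms (6 carbon, 2 nitrogen; one five-membered aromatic ring with 2 hetero atoms) in place of a group of 8 heavy atoms (6 carbon, 2 chlorine; one six-membered aromatic ring of carbon only), on a carbonyl carbon. Among the compounds with values here, no measured step joins a six-membered carbon ring to a charged five-membered ring on this carbonyl carbon; the only readable steps, both away from the 2-methylphenyl of compound 1, were large rises. Starting from a limit, the step from compound 3 to compound 4 is expected to be a step that the limit leaves unreadable from compound 3 to compound 4, likely unreadable again. Compound 4 is estimated at 8 ug/mL in this assay, within 2 ug/mL to 40 ug/mL, with a fair chance that only a limit is reported.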

Compound 4, half-maximal effective concentration: 0.012 ug/mL
Estimate against measurement, compound 4: 670-fold (2.82 log units) above; measured number below the stated range.
By their numbers in this assay, from the lowest: compound 4; then compound 1; then compound 2.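

On this carbonyl carbon, a six-membered carbon ring is not required for an effect at small amounts in this assay: the five-membered aromatic ring with net charge +1 gives an at least 330-fold lower number from compound 3 to compound 4 (2.52 log units; beyond the scatter) and a 410-fold lower number from compound 2 to compound 4 (2.61 log units; beyond the scatter). The ring type alone does not decide the read-out, as compound 1 also carries a six-membered carbon ring and the remaining gap is the more modest a 7.1-fold lower number from compound 1 to compound 4 (0.85 log units; beyond the scatter). Compound 3 gives only a limit and not a number: the limit of > 4 ug/mL in this assay, at which 1 of the 4 values shown sits.

Compound 4 changes ring size, hetero atoms, hydrogen-bond donor count and net charge in one step, so the compounds shown do not separate these features. Going by these compounds, how a pyridine, an unsubstituted pyrazole or a carboxylic acid would read on this carbonyl carbon remains open.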